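A Cyano-Triazole Replaces Methylamino on the Shared Core

The source may hold more compounds than are shown below. What is called first, only, known or untested is meant among the compounds shown, and "the series" means these compounds.

Compound 2 `CNc1nc(NC)nc(NC2(C#N)CCCCC2)n1` stands at a limit of an in vitro assay on Sf21 cells for inhibition of high affinity 3',5'-cyclic-AMP phosphodiesterase 7A (Homo sapiens); on this read-out lower numbers stand for stronger inhibition and higher numbers for weaker inhibition: it gives > 1000 nM, which is a limit and not a number. Compound 1 `CNc1nc(NC2CCCC2)nc(NC2(C#N)CCCCC2)n1` gives > 5000 nM in this assay, again a limit. Compound 3 `CNc1nc(NC2(C#N)CCCCC2)nc(N(C)C)n1` gives > 5000 nM in this assay, also a limit. Accordingly the steps a step that the two limits leave unreadable from compound 1 to compound 2, a step that the two limits leave unreadable from compound 1 to compound 3 and a step that the two limits leave unreadable from compound 2 to compound 3 are all unreadable, and none of them touches the change now considered. Compound 4 `CNc1nc(NC2(C#N)CCCCC2)nc(-n2cnc(C#N)n2)n1` differs from compound 2 by 3-cyano-1H-1,2,4-triazol-1-yl in place of methylamino on an aromatic carbon, placed on an aromatic carbon between two ring nitrogen atoms. Among the measured compounds shown here, no measured step bears on this exchange, so the expected step of an at least 3.3-fold lower number from compound 2 to compound 4 (0.52 log units; beyond the scatter) rests on the structural change alone and carries wide uncertainty. Compound 4 is estimated at 300 nM, within 40 nM to 3000 nM.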

Compound 4, half-maximal inhibitory concentration: > 5000 nM
Compound 4: a limit, no number (the forecaster's own chance of this, stated with the estimate: 30%); middle value at least 16-fold (1.22 log units) from the limit.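

Compound 4 gives > 5000 nM, a limit and not a number, so its steps from compound 1, compound 2 and compound 3 cannot be read. The compounds shown leave open whether 3-cyano-1H-1,2,4-triazol-1-yl in place of methylamino changes inhibition at all.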